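The compounds below may be only part of what the source reports. "The series", "measured", "known", "first", "only" and "open" are said of these compounds alone.

In a functional assay on HT-29 cells (Homo sapiens) for inhibition, read by MTT assay, with a stated time of 72 h (a higher number here means a weaker inhibitor, a lower number a stronger inhibitor), compound 1 (`C=C(Br)C(=O)Nc1cccc(/C=C/C(=O)Nc2ccc(C)cc2)c1`) gives 1200 nM and compound 2 (`C=C(Br)C(=O)Nc1cccc(/C=C/C(=O)Nc2ccc(OC)cc2)c1`) gives 2300 nM, so compound 2 stands level with compound 1 within the usual scatter. Compound 3 (`C=C(Br)C(=O)Nc1cccc(/C=C/C(=O)Nc2ccc(OC(F)(F)F)cc2)c1`) has not yet been measured. It departs from compound 2 in one place: trifluoromethyl in place of methyl on an oxygen on an aromatic ring. In words, trifluoromethyl stands in place of methyl on an oxygen on an aromatic ring, turning methoxy into trifluoromethoxy. Within the data shown here, only one measured step bears on this change, and it also alters a single small group on the aromatic ring: a 1.9-fold higher number from compound 1 to compound 2 (0.28 log units; within the scatter). It is a weak guide, since it involves no fluorine, but it offers no reason to expect a large shift. No step beyond the scatter is therefore expected in this assay, in either direction. The estimated step is a 1.2-fold lower number from compound 2 to compound 3 (0.06 log units; within the scatter). Compound 3 is expected at 2000 nM, within an estimated range of 800 nM to 5000 nM.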

Compound 3, half-maximal inhibitory concentration: 61200 nM
Beside the measured number, compound 3's estimate is 31-fold (1.49 log units) below it; the whole stated range lies below it.
By their numbers in this assay, from the lowest: compounds 1 and 2 (each within the scatter of the next); then compound 3.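

The oxygen on the aromatic ring proves a sensitive place in this assay: trifluoromethyl in place of methyl there gives a 27-fold higher number from compound 2 to compound 3 (1.43 log units; beyond the scatter) and so moves the number well beyond the scatter, which the earlier change from methyl to methoxy on the aromatic carbon did not do. Measured against the methyl compound, the trifluoromethoxy group gives a 51-fold higher number from compound 1 to compound 3 (1.71 log units; beyond the scatter) and confirms that a single small substituent on the shared core can cost much of the activity in these cells. Nothing shown here accounts for this loss.

The compounds leave open whether one or two fluorines on the methoxy group would already bring such a loss. They also leave open how a chlorine, an ethoxy group, an amine or a carboxylic acid at this place would compare with compound 1 and compound 3.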